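This account rests on a few compounds, and the source may have more. Where it says the series, first, only, none or still open, it means among the compounds named here.

In a functional assay on HL-60 cells (Homo sapiens) for antiproliferative activity, read by MTT assay (on this read-out lower numbers stand for stronger inhibition and higher numbers for weaker inhibition), compound 1 `CC[C@H]1O[C@H](COCc2ccccc2)[C@@H](OCc2ccccc2)[C@H](OCc2ccccc2)[C@H]1O` is recorded as "not active" (no number reported), so the series has no numerical starting point. The next compound to consider is compound 3 `C=C[C@H]1O[C@H](COCc2ccccc2)[C@@H](OCc2ccccc2)[C@H](OCc2ccccc2)[C@H]1O`, which has not yet been tested. The core stays the same and a single group changes: vinyl in place of ethyl on a saturated ring carbon. Among the measured compounds shown here, the only measured number nearby comes from compound 2 `C=CC[C@@H]1O[C@H](COCc2ccccc2)[C@@H](OCc2ccccc2)[C@H](OCc2ccccc2)C1=O`, which gives 31800 nM in this assay but differs from compound 1 in more than one place, so it is only a loose guide. A change this small is expected to produce at most a modest step toward stronger inhibition in this assay, and compound 3 may well remain inactive. If a number is reported, the estimated value for compound 3 is 45000 nM, with an expected range from 15000 nM to 100000 nM in this measurement.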

Compound 3, half-maximal inhibitory concentration: "not active" (no number reported)
For compound 3 the study gives words and no number, and the estimate cannot be compared.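

Compound 1 and compound 3 are both recorded as not active without a number, so no step can be read from the change of ethyl to vinyl. The compounds shown leave open whether this change alters inhibition at all. No measurement shown here offers an explanation for this result.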